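Amide nitrogen substituent and cytotoxicity in the thiadiazole series

The source may hold more compounds than are shown below. What is called first, only, known or untested is meant among the compounds shown, and "the series" means these compounds.

Going by the values given here, compound 1 `O=C(CCSc1nnc(-c2ccncc2)s1)Nc1ccc(Cl)cc1` is the only member of the set with a single number in an ADME assay on BHK-21 cells (Mesocricetus auratus) for cytotoxicity, with a stated time of 3 days (on this read-out lower numbers stand for higher toxicity in this test and higher numbers for lower toxicity in this test), where compound 1 gives 8210 nM. Compound 2 `CC(Sc1nnc(-c2ccncc2)s1)C(=O)NCc1ccccc1Cl` reaches only the limit of this assay, reported as > 50000 nM; this is a limit of the test and not a number. Compound 3 `CC(CSc1nnc(-c2ccncc2)s1)C(=O)NCc1ccc(Cl)cc1` has no result in this assay, the entry being "not determined" (no result reported). Of the three values shown, one sits at the limit (the limit of > 50000 nM in this assay, at which 1 of the 3 values shown sits).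

Among the compounds with values here, no pair of measured compounds differs in one place, so no measured step is available. Compound 4 `O=C(CCSc1nnc(-c2ccncc2)s1)NCc1ccccc1` differs from compound 1 by benzyl in place of 4-chlorophenyl on an amide-type nitrogen, in words: benzyl in place of 4-chlorophenyl on an amide-type nitrogen.

The expectation is a moderate shift toward lower toxicity, beyond the scatter, with a fair chance that only a limit is returned. Compound 4 is expected to give about 20000 nM in this assay, within 6000 nM to 60000 nM. The step of a 2.4-fold higher number from compound 1 to compound 4 (0.39 log units; beyond the scatter) is thus estimated as a move toward the less toxic end.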

Compound 4, half-maximal cytotoxic concentration: 18700 nM
Compound 4: the middle estimate sits 1.1-fold (0.03 log units) above what was measured, within the range that was stated.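

Going by these compounds alone, replacing 4-chlorophenyl with benzyl on the amide-type nitrogen gives a 2.3-fold higher number from compound 1 to compound 4 (0.36 log units; beyond the scatter) in this assay, the only step that can be read, and it shows that this position bears on the read-out. Compound 4 returns a number and not a limit, so both ends of the step are fixed and its size is known. Compound 2 stays at a limit of the test and cannot be placed on this scale: the limit of > 50000 nM in this assay, at which 1 of the 4 values shown sits.

The step combines the loss of the chlorine with the change from phenyl to benzyl, and a plain phenyl on this nitrogen would separate the two. Also open, on these data alone, is whether phenethyl, a longer chain on this nitrogen, or a carboxylic acid on the benzyl ring would move the number further.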